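Chloro for Methyl on a Glutamate Receptor Modulator

A few compounds are considered here, and "the series" means these few. Any claim that something is new, unique, unknown or untested is made for them only; others in the source may bear on it.

Of the compounds shown here, three built on one shared core have been measured. Compound 1 `Cc1cc(C(=O)O)ccc1OCCCCOc1ccc(C(=O)CC(C)C)c(O)c1C` gives 83.9% in an assay on HEK293 cells for positive allosteric modulation of metabotropic glutamate receptor 2 (Rattus norvegicus), read by thallium flux, with a stated time of 2.5 min; a higher number here means a larger maximal response, a lower number a smaller maximal response. Compound 2 `Cc1c(OCCCCOc2ccc(C(=O)O)cc2Cl)ccc(C(=O)CC(C)C)c1O` gives 99.5% in this assay, and compound 3 `Cc1cc(OCCCCOc2ccc(C(=O)CC(C)C)c(O)c2C)ccc1C(=O)O` gives 93.3%. Compound 1 and compound 2 differ by a single change, (chloro in place of methyl on an aromatic carbon), and that change made a step of a number 15.6 percentage points higher from compound 1 to compound 2 (beyond the scatter). The cores of compound 1 and compound 3 differ as follows: 4-carboxy-3-methylphenyl in place of 4-carboxy-2-methylphenyl on an oxygen on a saturated carbon. That difference gave a number 9.4 percentage points higher from compound 1 to compound 3 (within the scatter), and between the remaining pair there is a number 6.2 percentage points lower from compound 2 to compound 3 (within the scatter).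

Compound 4 `Cc1c(OCCCCOc2ccc(C(=O)O)c(Cl)c2)ccc(C(=O)CC(C)C)c1O` has not yet been measured. It arises from compound 3 by chloro in place of methyl on an aromatic carbon. Among the four compounds this swap of chloro for methyl occurs twice, yet the two cases are the same kind of change rather than the same one: in compound 2 the chloro stands ortho to a large group and meta to a carboxy group, while in compound 4 it stands ortho to a carboxy group and meta to a large group. A rise is expected for compound 4 because the earlier swap gave a number 15.6 percentage points higher from compound 1 to compound 2 (beyond the scatter), but a smaller one is estimated, since the surroundings of the new group differ. Compound 4 is therefore expected to reach 98%, somewhere between 86% and 110%, which would be an estimated step of a number 4.7 percentage points higher from compound 3 to compound 4 (within the scatter).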

Compound 4, largest response reached (reported as percent of maximum), in percent of the reference or control that the assay uses: 80.5%
The estimate for compound 4 lay 17.5 percentage points above the measured number, and the stated range ends above it.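

In this assay, chloro in place of methyl did not carry over from one core to the other, and the two steps even point in opposite directions: the same change on two cores in this assay, a number 15.6 percentage points higher (beyond the scatter) from compound 1 to compound 2 and a number 12.8 percentage points lower (beyond the scatter) from compound 3 to compound 4, 28.4 percentage points apart, beyond the scatter of two such steps. The swap on the core of compound 3 gave a number 12.8 percentage points lower from compound 3 to compound 4 (beyond the scatter), and 4-carboxy-3-chlorophenyl in place of 4-carboxy-2-chlorophenyl gave a number 19 percentage points lower from compound 2 to compound 4 (beyond the scatter), so in these compounds the outcome of adding a chloro depends on where on the ring it is placed, while the two differences separating the last pair leave a number 3.4 percentage points lower from compound 1 to compound 4 (within the scatter). Among these compounds, this shows that a step measured on one core is a poor guide to the same swap on the other core, but with only two such pairs it gives no general rule and does not explain why the steps differ.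

The compounds shown leave open how other groups would behave on the same aromatic carbon, such as fluoro, bromo or methoxy in place of the chloro. They also leave open whether the opposite steps would persist with a longer chain between the two oxygens, or with an amide in place of the carboxy group.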